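This account rests on a few compounds, and the source may have more. Where it says the series, first, only, none or still open, it means among the compounds named here.

Compound 1, `CC1=C(N2CC2)C(=O)C(CC(C)OC(N)=O)=C(N2CC2)C1=O`, in a functional assay on L1210 cells (Mus musculus), with a stated time of 12 days (a lower number here means a less potent compound, a higher number a more potent compound, by a factor of ten per unit of this negative logarithm), gives 5.79.
Compound 2, `CC1=C(N2CC2)C(=O)C(CCCOC(N)=O)=C(N2CC2)C1=O`, in this assay gives 5.93.
Compound 3, `CCOC(COC(N)=O)C1=C(N2CC2)C(=O)C(C)=C(N2CC2)C1=O`, in this assay gives 5.22.

All three share the same core and differ only in the side chain attached to it. Compound 3 stands lowest of the three measured values in this assay: compound 1 lies closest to it, yet the gap between them is beyond the usual scatter, and compound 2 lies furthest from it. The step of a number 0.14 log units higher from compound 1 to compound 2 (within the scatter) shows that moving the side-chain methyl along the chain leaves the result within the scatter.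

Compound 4, `CC1=C(N2CC2)C(=O)C(C(C)COC(N)=O)=C(N2CC2)C1=O`, has not yet been measured. It arises from compound 3 by the change (methyl in place of ethoxy on a saturated chain carbon bound to a double-bonded ring carbon and a saturated chain carbon). Among the measured compounds shown here, no measured pair tells how this particular exchange behaves, so the only guidance is indirect: compound 4 carries a chain without the ethoxy, much like compound 1 and compound 2, and both of those stand well above compound 3. The expectation is therefore a rise in this assay, by a step of about a number 0.48 log units higher from compound 3 to compound 4 (beyond the scatter), though with wide uncertainty since it rests on resemblance rather than a directly measured step. For compound 4 the estimated value in this assay is 5.7, expected to fall between 5.2 and 6.2.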

Compound 4, logarithm of the reciprocal of the active concentration, log(1/C): 5.71
For compound 4 the middle estimate is 0.01 log units below the measured one, within the range that was stated.
By their numbers in this assay, from the lowest: compound 3; then compounds 4, 1 and 2 (each within the scatter of the next).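

In this assay, among the compounds shown here, exchanging ethoxy for methyl on a saturated chain carbon bound to a double-bonded ring carbon and a saturated chain carbon gives the first direct measurement at this position: a number 0.49 log units higher from compound 3 to compound 4 (beyond the scatter). This single exchange is enough to bring the compound level with the other two, as a number 0.22 log units lower from compound 2 to compound 4 (within the scatter) and a number 0.08 log units lower from compound 1 to compound 4 (within the scatter), so the three methyl-bearing or extended side chains of compound 1, compound 2 and compound 4 cannot be told apart in this read-out, whichever way their carbons are arranged. Nothing available explains why this exchange produces the step seen.

With only ethoxy and methyl compared on this carbon, the compounds shown leave open how a methoxy group, a hydroxyl group, a bare hydrogen or a longer chain such as propyl would behave there, and a methoxy group in particular could help separate the effect of the oxygen from that of the extra carbons. They also leave open whether the same step would appear with a different group in place of the shared core's other substituents.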